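This account rests on a few compounds, and the source may have more. Where it says the series, first, only, none or still open, it means among the compounds named here.

Measured compounds:
compound 1, `CCCOC(=O)C1=C(C)NC(=O)NC1c1cccs1`, 43%
compound 2, `CCCC(=O)C1=C(C)NC(=O)NC1c1cccs1`, 2%
compound 3, `CC1=C(C(=O)SC(C)C)C(c2cccs2)NC(=O)N1`, 1%

These three share one core and differ only in the group on the carbonyl carbon. In an assay on membranes from CHO cells for displacement of a labelled ligand from adenosine receptor A1 (Homo sapiens), read by scintillation counting, with a stated time of 60 min, tested at 1 uM (on this read-out higher numbers stand for more inhibition at the one concentration tested (going by the name of the read-out) and lower numbers for less inhibition), compound 1 gives 43%, compound 2 gives 2% and compound 3 gives 1%. Compound 3 thus has the lowest number of the three, though the gap a number 1 percentage points lower from compound 2 to compound 3 (within the scatter) means compound 2 and compound 3 cannot be told apart, while the gap a number 42 percentage points lower from compound 1 to compound 3 (beyond the scatter) is large.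

Compound 4, `CC1=C(C(=O)OCC2CCC2)C(c2cccs2)NC(=O)N1`, is not yet measured. It differs from compound 3 in one place: cyclobutylmethoxy in place of isopropylsulfanyl on a carbonyl carbon. The step that bears on this change most directly is a number 42 percentage points lower from compound 1 to compound 3 (beyond the scatter), since compound 4 restores an oxygen-linked group on the carbonyl carbon as in compound 1, although the group is cyclobutylmethoxy rather than propoxy. A return toward the number of compound 1 is therefore expected, with real uncertainty about how far. Compound 4 is estimated at 33%, between 8% and 60%, an expected step of a number 32 percentage points higher from compound 3 to compound 4 (beyond the scatter).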

Compound 4, a percentage reported as inhibition, at one concentration (the size of the read-out at that concentration, not a potency): 39%
For compound 4 the middle estimate is 6 percentage points below the measured one; the range from low to high includes it.
By their numbers in this assay, from the lowest: compounds 3 and 2 (each within the scatter of the next); then compounds 4 and 1 (each within the scatter of the next).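

In this assay the step of a number 38 percentage points higher from compound 3 to compound 4 (beyond the scatter) and the step of a number 37 percentage points higher from compound 2 to compound 4 (beyond the scatter) show that a second oxygen-linked group on the carbonyl carbon, cyclobutylmethoxy, also stands well clear of the sulfur-linked isopropylsulfanyl and the carbon-linked propyl. The step of a number 4 percentage points lower from compound 1 to compound 4 (within the scatter) shows that replacing the ethyl of the propoxy chain with a cyclobutyl ring leaves no readable difference, so this position accepts a ring at the end of the oxygen-linked chain. Across these four compounds, the two with an oxygen on the carbonyl carbon give the higher numbers, and none goes against this.

No measurement shown gives a reason for these differences. Going by these compounds, how a nitrogen-linked group such as propylamino, or a longer chain such as hexyloxy, would behave at this position remains open.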